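Hydroxy in Place of Bromo on the Hydrazone Aryl Ring

A few compounds are considered here, and "the series" means these few. Any claim that something is new, unique, unknown or untested is made for them only; others in the source may bear on it.

Three hydrazones sharing one core have been tested in an ADME assay on NIH3T3 cells (Mus musculus) for cytotoxicity, read by MTT assay, with a stated time of 24 h; on this read-out higher numbers stand for weaker inhibition and lower numbers for stronger inhibition. Compound 1 `O=C(CSc1nnc(-c2ccncc2)o1)N/N=C/c1ccccc1` gives 167000 nM, compound 2 `O=C(CSc1nnc(-c2ccncc2)o1)N/N=C/c1ccc(Cl)cc1` gives 181000 nM, and compound 3 `O=C(CSc1nnc(-c2ccncc2)o1)N/N=C/c1ccc(Br)cc1` gives 169000 nM. Compound 3 holds the second highest of the three numbers, nearest to compound 1 and furthest from compound 2, with every gap within the scatter. The next compound, compound 4 `O=C(CSc1nnc(-c2ccncc2)o1)N/N=C/c1ccc(O)cc1`, differs from compound 3 by hydroxy in place of bromo on an aromatic carbon. Within the data shown here, no measured step introduces a hydroxy group, but the substitutions at this same position, a 1.0-fold higher number from compound 1 to compound 3 (0.01 log units; within the scatter) and a 1.1-fold lower number from compound 2 to compound 3 (0.03 log units; within the scatter), both stayed within the scatter, as did a 1.1-fold higher number from compound 1 to compound 2 (0.03 log units; within the scatter). Compound 4 is therefore expected to give 170000 nM, between 85000 nM and 340000 nM, an expected step of a 1.0-fold higher number from compound 3 to compound 4 (0.00 log units; within the scatter) that stays within the scatter.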

Compound 4, half-maximal inhibitory concentration: 158000 nM
The estimate for compound 4 lay 1.1-fold (0.03 log units) above the measured number; low and high end bracket the measured number.
By their numbers in this assay, from the lowest: compounds 4, 1, 3 and 2 (each within the scatter of the next).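

In this assay, among these compounds, the first group at this position to bring a hydrogen-bond donor and acceptor behaved like the halogens, with every step within the scatter: hydroxy for bromo (a 1.1-fold lower number from compound 3 to compound 4 (0.03 log units; within the scatter)), for chloro (a 1.1-fold lower number from compound 2 to compound 4 (0.06 log units; within the scatter)) and for hydrogen (a 1.1-fold lower number from compound 1 to compound 4 (0.02 log units; within the scatter)). All four compounds therefore remain indistinguishable on this read-out. No evidence is available to explain this result.

On these data alone, whether an amine, a carboxylic acid or a longer chain at this position would give a step beyond the scatter remains open. So does the effect of changes elsewhere on the shared core.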